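The source may hold more compounds than are shown below. What is called first, only, known or untested is meant among the compounds shown, and "the series" means these compounds.

In an ADME assay on MDCK cells (Canis lupus familiaris) for cytotoxicity, with a stated time of 48 h (a higher number here means that more compound is tolerated, a lower number that less compound is tolerated), compound 2 `CCC(CC)O[C@@H]1C=C(S(=O)(=O)O)C[C@H](N)[C@H]1NC(C)=O` reads > 100000 nM as a limit of the assay and not as a number. Compound 1 `CCC(CC)O[C@@H]1C=C([S+]([O-])O)C[C@H](NC(=N)N)[C@H]1NC(C)=O` reads > 100000 nM and that too is a limit. Compound 2 therefore has no exact place on the scale. Compound 3 `CCC(CC)O[C@@H]1C=C(S(=O)(=O)O)C[C@H](NC(=N)N)[C@H]1NC(C)=O` has not yet been measured. Its difference from compound 2 is a group of 3 heavy atoms (1 carbon, 2 nitrogen; no ring) in place of a hydrogen atom, on an amine nitrogen and it falls on an amine nitrogen attached to a saturated ring carbon. Among the compounds with values here, no measured step shows what such a change does in this assay and the only guide is the limit of > 100000 nM in this assay, at which 2 of the 2 values shown sit, so no move beyond the scatter is expected in either direction. The estimated step of a number no higher from compound 2 to compound 3 (the limit leaves the size open) is accordingly small. For compound 3 the expected value is 100000 nM with an estimated range of 50000 nM to 200000 nM and the assay may well report only a limit again.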

Compound 3, half-maximal cytotoxic concentration: > 100000 nM
Compound 3: only a limit was reported; the forecaster's own chance of this, stated with the estimate: 90%; the middle value lies on the limit itself.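

With compound 3 reported only as a limit, neither the step from compound 1 to compound 3 nor the step from compound 2 to compound 3 can be read: the limit of > 100000 nM in this assay, at which 3 of the 3 values shown sit. The compounds shown leave open where any of the three would lie on the scale of this assay.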